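The source may report more compounds than this note shows. Statements on the series, on what has been measured and on what is new or still open speak of the compounds shown alone.

Compound 1 `Cn1c(/C=C/C(=O)c2ccccc2O)cc(Br)c1Br` and compound 2 `O=C(/C=C/c1cc(Br)c(Br)[nH]1)c1ccccc1O` share a core and differ by a single change: methyl in place of hydrogen on an aromatic nitrogen. In a functional assay on Caco-2 cells (Homo sapiens) for cytotoxicity, read by MTT assay, with stated times of 6 h and 48 h (on this read-out higher numbers stand for weaker inhibition and lower numbers for stronger inhibition), compound 1 gives 3160 nM. In this assay compound 2 gives only a limit, >= 100000 nM. That pair yields an at least 31-fold lower number from compound 2 to compound 1 (1.50 log units; beyond the scatter), a step that rests on (the limit of >= 100000 nM in this assay, at which 2 of the 3 values shown sit). Compound 3 `O=c1cc(-c2cc(Br)c(Br)[nH]2)oc2ccccc12` carries a different core; how the core of compound 3 differs from that of compound 2 is not broken down here. In this assay compound 3 also gives only a limit, >= 100000 nM. Compound 4 `Cn1c(-c2cc(=O)c3ccccc3o2)cc(Br)c1Br` is not yet measured, and it stands to compound 3 as compound 1 stands to compound 2, by the same change: methyl in place of hydrogen on an aromatic nitrogen. Seen beside the earlier step, the step expected in this assay is an at least 4.0-fold lower number from compound 3 to compound 4 (0.60 log units; beyond the scatter), resting on the step from compound 2 to compound 1 an at least 31-fold lower number from compound 2 to compound 1 (1.50 log units; beyond the scatter), though the starting point of compound 3 is only a limit. Compound 4 is therefore estimated at 25000 nM.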

Compound 4, half-maximal inhibitory concentration: >= 100000 nM
Compound 4: only a limit was reported (the forecaster's own chance of this, stated with the estimate: 40%); middle value at least 4.0-fold (0.60 log units) from the limit.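

Compound 3 and compound 4 both give only a limit in this assay, so no step between them can be read: the limit of >= 100000 nM in this assay, at which 3 of the 4 values shown sit.

The compounds shown leave open whether methyl in place of hydrogen on an aromatic nitrogen changes the read-out at all on the core of compound 3, and where the true numbers of these two compounds lie.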